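Side-chain swap on a carbonyl carbon

The source may report more compounds than this note shows. Statements on the series, on what has been measured and on what is new or still open speak of the compounds shown alone.

Of the compounds shown here, two have numbers so far in an ADME assay on tissue (MIA PaCa-2 cells, Homo sapiens) for pharmacokinetics; a lower number here means that the compound disappears faster, a higher number that the compound lasts longer. Compound 1 (`N[C@@H](CCC(=O)OC[C@H]1O[C@@H](n2cc(F)c(=O)[nH]c2=O)C[C@@H]1OC(=O)CC[C@H](N)C(=O)O)C(=O)O`) gives 0.292 h, and compound 2 (`CC(C)[C@H](N)C(=O)OC[C@H]1O[C@@H](n2cc(F)c(=O)[nH]c2=O)C[C@@H]1O`) gives 0.188 h. These two values lie within the scatter of each other, so compound 2 does not stand apart from compound 1 on the present numbers.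

Compound 3 (`N[C@@H](CCC(=O)OC[C@H]1O[C@@H](n2cc(F)c(=O)[nH]c2=O)C[C@@H]1O)C(=O)O`) has not yet been measured. It differs from compound 2 in one place, on a carbonyl carbon, with 3-amino-3-carboxypropyl in place of 1-amino-2-methylpropyl on a carbonyl carbon. Among the measured compounds shown here, no measured step isolates this change, so the expectation rests on only two values. The entering 3-amino-3-carboxypropyl also occurs in compound 1, which gives 0.292 h. On that limited basis, no change beyond the scatter is expected in this assay, and any direction is only tentative. The estimated step of a 1.3-fold higher number from compound 2 to compound 3 (0.12 log units; within the scatter) is therefore small. For compound 3, the expected half-life is 0.25 h, with an estimated range of 0.12 h to 0.5 h.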

Compound 3, half-life: 0.335 h
Estimate against measurement, compound 3: 1.3-fold (0.13 log units) below; the measured number falls inside the stated range.
By their numbers in this assay, from the lowest: compounds 2, 1 and 3 (each within the scatter of the next).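

In this assay the exchange of 1-amino-2-methylpropyl for 3-amino-3-carboxypropyl on a carbonyl carbon now has a direct reading of a 1.8-fold higher number from compound 2 to compound 3 (0.25 log units; within the scatter) and so gives no separable difference at this position. The second side of the series can now also be read, with hydrogen in place of (3-amino-3-carboxypropyl)carbonyl on an oxygen on a saturated carbon giving a 1.1-fold higher number from compound 1 to compound 3 (0.06 log units; within the scatter) and so no separable contribution from that extra acyl group. Both one-place changes thus stay inside the scatter, and compounds 1, 2 and 3 cannot be told apart by half-life, although the side chains differ in size and in the presence of a carboxylic acid. No supporting data bear on why these steps are as small as they are.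

The compounds shown leave open whether any group on this carbonyl carbon can move the half-life beyond the scatter, for example a longer chain or a phenyl ring. On these data alone, it also remains open whether an amide in place of the ester link, with the same 3-amino-3-carboxypropyl side chain, would read any differently.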